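A few compounds are considered here, and "the series" means these few. Any claim that something is new, unique, unknown or untested is made for them only; others in the source may bear on it.

Measured so far in a functional assay on NALM-6 cells (Homo sapiens) for antiproliferative activity, read by MTT assay and trypan blue exclusion, with a stated time of 72 h; a lower number here means a stronger inhibitor, a higher number a weaker inhibitor:
compound 1 `COC(=O)c1ccc(C2SCC(=O)N2c2ccc(N3CCN(Cc4cccc([N+](=O)[O-])c4)CC3)cn2)c(OC)c1` — > 100000 nM
compound 2 `COC(=O)c1ccc(C2SCC(=O)N2c2ccc(N3CCN(S(=O)(=O)c4ccc([N+](=O)[O-])cc4)CC3)cn2)c(OC)c1` — > 100000 nM
compound 3 `COC(=O)c1ccc(C2SCC(=O)N2c2ccc(N3CCN(Cc4cc(OC)c(OC)c(OC)c4)CC3)cn2)c(OC)c1` — > 100000 nM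

Each of these values is a limit of this assay, not a number. Compound 2 stands at that limit. Compound 1 and compound 3 stand at the same limit, so all three values shown sit at the limit of > 100000 nM in this assay, at which 3 of the 3 values shown sit. The two measured steps that touch this part of the series, a step that the two limits leave unreadable from compound 1 to compound 2 and a step that the two limits leave unreadable from compound 1 to compound 3, are thus of unreadable size and give no direction.

Compound 4 `COC(=O)c1ccc(C2SCC(=O)N2c2ccc(N3CCN(S(=O)(=O)c4c(C)cc(C)cc4C)CC3)cn2)c(OC)c1` is not yet measured. It differs from compound 2 by 2,4,6-trimethylphenyl in place of 4-nitrophenyl on a sulfonyl sulfur. Among the measured compounds shown here, no measured step of readable size bears on a change of this kind; the only steps available are the two unreadable ones, both sitting at the limit. The expectation for compound 4 in this assay therefore rests on compound 2 remaining at the limit of > 100000 nM in this assay, at which 3 of the 3 values shown sit. The estimated step is a step that the limit leaves unreadable from compound 2 to compound 4, nothing beyond the scatter. Compound 4 is estimated at 150000 nM, within a range from 40000 nM to 600000 nM, and is expected most likely to be reported again only as a limit.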

Compound 4, half-maximal inhibitory concentration: > 100000 nM
Compound 4: no number, only a limit; the forecaster's own chance of this, stated with the estimate: 85%; the middle value does not contradict the limit.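

Compound 4 gives > 100000 nM, a limit and not a number. The steps to it from compound 1 and compound 2 therefore cannot be read. The compounds shown leave open whether any group on the amine nitrogen in the ring gives a readable value, as all remain at one limit: the limit of > 100000 nM in this assay, at which 4 of the 4 values shown sit.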